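Thioether diacid series: methylating the sulfonamide nitrogen

The source may hold more compounds than are shown below. What is called first, only, known or untested is meant among the compounds shown, and "the series" means these compounds.

The series keeps a shared core and varies the linker leading to the chlorinated end group; all members are followed in an assay on isolated protein for inhibition of ATP-citrate synthase (Rattus norvegicus); on this read-out higher numbers stand for weaker inhibition and lower numbers for stronger inhibition. Compound 1 `O=C(O)CC(O)(CSCc1ccc(Cl)cc1Cl)C(=O)O`, with the shortest linker, gives 410000 nM. Compound 2 `O=C(O)CC(O)(CSCCCC/C=C\c1ccc(Cl)cc1Cl)C(=O)O`, with an extended unsaturated chain, gives 33000 nM. Compound 3 `O=C(O)CC(O)(CSCCCCNS(=O)(=O)c1ccc(Cl)cc1Cl)C(=O)O`, whose chain carries a sulfonamide, gives 175000 nM. On these three numbers compound 3 stands second highest: the number of compound 1 lies above it by a margin beyond the scatter, and the number of compound 2 lies below it by a larger margin, also beyond the scatter. Within the data shown here, no pair among the measured compounds differs in only one place, so no single-step comparison is available.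

Compound 4 `CN(CCCCSCC(O)(CC(=O)O)C(=O)O)S(=O)(=O)c1ccc(Cl)cc1Cl` is the next member. It differs from compound 3 in one place: methyl in place of hydrogen on a sulfonamide nitrogen. Among the measured compounds shown here, nothing among the measured compounds shows what the hydrogen that leaves contributes, so no direction can be read from the series; the change is small and the expectation is a step not beyond the scatter in either direction. The expected step, a 1.1-fold lower number from compound 3 to compound 4 (0.04 log units; within the scatter), lies within the usual scatter of this assay. Compound 4 is accordingly estimated at 160000 nM, with a range from 60000 nM to 420000 nM.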

Compound 4, inhibition constant: 178000 nM
Estimate against measurement, compound 4: 1.1-fold (0.05 log units) below; the range from low to high includes it.
By their numbers in this assay, from the lowest: compound 2; then compounds 3 and 4 (each within the scatter of the next); then compound 1.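

In this assay, among these compounds, the step for methyl in place of hydrogen on the sulfonamide nitrogen is a 1.0-fold higher number from compound 3 to compound 4 (0.01 log units; within the scatter) and so gives the first single-place reading. At this position, the hydrogen of compound 3 can therefore give way to methyl with the two numbers standing level, so the hydrogen is not required to hold the number in this assay, and one added carbon on this nitrogen can be accommodated. No measurement available here bears on why the two numbers stand level.

Going by these compounds, whether this holds only for methyl stays open: an ethyl, a benzyl or an acetyl group on the same nitrogen would show whether larger groups are accepted there as well. Also open, on these data alone, is what the sulfonamide itself contributes to the linker, which a carboxamide in its place on the same chain, or a longer chain carrying the same N-methyl sulfonamide, would begin to separate from the effect of linker length.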